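One Change on a Carbonyl Carbon of the Shared Core

A few compounds are considered here, and "the series" means these few. Any claim that something is new, unique, unknown or untested is made for them only; others in the source may bear on it.

Compound 1, `COc1cc(NCc2ccccc2)cc(OC)c1OC`, gives in a functional assay on HCT-116 cells (Homo sapiens) for inhibition, read by MTT assay, with a stated time of 48 h (on this read-out higher numbers stand for weaker inhibition and lower numbers for stronger inhibition), only a limit of the assay, > 80000 nM.
Compound 2, `COC(=O)c1cc(CNc2cc(OC)c(OC)c(OC)c2)ccc1OC`, gives in this assay 38100 nM.
Compound 3, `C#CC(=O)N(Cc1ccc(OC)c(O)c1)c1cc(OC)c(OC)c(OC)c1`, gives in this assay 310 nM.

Compound 3 thus holds the lowest of the two numbers; its nearest neighbour is compound 2, whose number is higher by a distance beyond the scatter. Compound 4, `COc1ccc(CN(C(=O)C[Se]C#N)c2cc(OC)c(OC)c(OC)c2)cc1O`, has not yet been measured. It differs from compound 3 in one place: a group of 4 heavy atoms (2 carbon, 1 nitrogen, 1 selenium; no ring) in place of a group of 2 heavy atoms (2 carbon; no ring), on a carbonyl carbon. Among the measured compounds shown here, no measured pair mirrors this change, so the expectation rests on the structural change alone. Compound 4 is expected to keep most of the activity of compound 3, with a step in this assay of a 1.9-fold higher number from compound 3 to compound 4 (0.29 log units; within the scatter) toward a higher number, near the edge of the scatter. The estimate for compound 4 is 600 nM, expected to lie between 150 nM and 2500 nM.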

Compound 4, half-maximal inhibitory concentration: 310 nM
Beside the measured number, compound 4's estimate is 1.9-fold (0.29 log units) above it; measured number inside the range.
By their numbers in this assay, from the lowest: compounds 3 and 4 (each within the scatter of the next); then compound 2. At a limit, above all of these: compound 1.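

In this assay, among the compounds shown here, the step of no change at the digits printed from compound 3 to compound 4 (within the scatter) gives the first reading at this place, on a carbonyl carbon whose other neighbour is an amide-type nitrogen. The ethynyl gives way there to a group of 4 heavy atoms that includes selenium, with no change beyond the scatter. Both groups carry a triple bond outside aromatic rings, so this single step does not test a group lacking one.

Going by these compounds, whether a methyl or an amine at this place would fare the same remains open. Nothing measured here bears on why the two groups fall within the scatter of each other.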